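Swapping Benzoyl for Acetyl: an Expected Loss of Potency

The compounds below may be only part of what the source reports. "The series", "measured", "known", "first", "only" and "open" are said of these compounds alone.

In a functional assay on NCI-H23 cells (Homo sapiens) for cytotoxicity, read by sulforhodamine B assay, with a stated time of 72 h (on this read-out higher numbers stand for weaker inhibition of growth and lower numbers for stronger inhibition of growth), compound 3 `O=C(Nc1ccccc1C(F)(F)F)C1CCc2ccccc2N1C(=O)c1ccccc1` gives 6340 nM, the lowest of the two numbers in hand; its nearest neighbour, compound 2 `O=C(Nc1ccccc1C(F)(F)F)C1CCc2ccccc2N1`, gives 56800 nM. For compound 1 `CCCC(=O)N1c2ccccc2CCC1C(=O)Nc1ccccc1C(F)(F)F` only a limit is known: in this assay compound 1 gives > 70000 nM, a limit rather than a number (the limit of > 70000 nM in this assay, at which 1 of the 3 values shown sits). Compound 4 `CC(=O)N1c2ccccc2CCC1C(=O)Nc1ccccc1C(F)(F)F` differs from compound 3 by methyl in place of phenyl on a carbonyl carbon. Going by the values given here, two measured steps bear on this change: a 9.0-fold lower number from compound 2 to compound 3 (0.95 log units; beyond the scatter), and an at least 11-fold lower number from compound 1 to compound 3 (1.04 log units; beyond the scatter). Both leave the benzoyl compound well ahead of a smaller acyl group or of none, so trading the phenyl for a methyl on that carbonyl carbon is expected to raise the number by a large step. Compound 4 is therefore estimated at 50000 nM, within 15000 nM to 150000 nM, a step of a 7.9-fold higher number from compound 3 to compound 4 (0.90 log units; beyond the scatter), with a fair chance that only a limit is reported.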

Compound 4, concentration for 50% growth inhibition: > 80000 nM
Compound 4: a limit, no number; the forecaster's own chance of this, stated with the estimate: 40%; middle value at least 1.6-fold (0.20 log units) away from the limit.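

Going from benzoyl to acetyl gives an at least 12-fold higher number from compound 3 to compound 4 (1.10 log units; beyond the scatter), so methyl joins propyl in falling well short of phenyl on this carbonyl carbon. Acetyl in place of hydrogen gives an at least 1.4-fold higher number from compound 2 to compound 4 (0.14 log units; that floor lies within the scatter), so acetyl, unlike benzoyl, shows no gain over hydrogen. The step linking compound 1 with compound 4 cannot be read, and compound 4 itself is only a limit: the limit of > 80000 nM in this assay, at which 1 of the 4 values shown sits.

The compounds shown leave open whether the gain needs an aromatic ring or would also come with a cyclohexyl group on that carbonyl carbon. They also leave open how a methoxy group or an amine on the phenyl would read.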